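Para-Bromo Aryloxymethyl Oxazoline: Expected Anti-Edema Dose

The source may hold more compounds than are shown below. What is called first, only, known or untested is meant among the compounds shown, and "the series" means these compounds.

Compound 1 `COc1ccc(OCC2=NCCO2)cc1`: 77.2 mg/kg
Compound 2 `Cc1ccccc1OCC1=NCCO1`: 78.3 mg/kg
Compound 3 `Clc1ccccc1OCC1=NCCO1`: 77.5 mg/kg

Of the compounds shown here, three of the shared core have been measured in a functional assay on the whole organism for inhibition, with Rattus norvegicus as the target, read by paw edema, with a stated time of 30 min; on this read-out lower numbers stand for an effect already at smaller amounts and higher numbers for an effect only at larger amounts of compound. In this assay compound 1 gives 77.2 mg/kg, and the three numbers sit together: compound 3 comes nearest to compound 1 and compound 2 furthest, yet neither gap reaches beyond the scatter, so compound 1 cannot be set apart from the other two.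

The next compound is compound 4 `Brc1ccc(OCC2=NCCO2)cc1`. It differs from compound 1 by bromo in place of methoxy on an aromatic carbon. For the measured compounds named here, only one measured step exists between compounds that differ in one place: chloro in place of methyl on an aromatic carbon gave a 1.0-fold lower number from compound 2 to compound 3 (0.00 log units; within the scatter). That step concerns a different pair of groups and a different place on the ring, so it bears on the change from compound 1 to compound 4 only in a general way: a single substituent swap on the aromatic ring of this core left the dose unmoved. Going by the values given here, no measured pair shows bromo in place of methoxy, and no pair varies the group on the same position as in compound 4.

The expectation for compound 4 is therefore no step beyond the scatter, expressed as a 1.0-fold lower number from compound 1 to compound 4 (0.00 log units; within the scatter). Compound 4 is estimated at 77 mg/kg, with a range from 45 mg/kg to 130 mg/kg.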

Compound 4, dose for half-maximal effect: 65.5 mg/kg
Beside the measured number, compound 4's estimate is 1.2-fold (0.07 log units) above it, within the range that was stated.
By their numbers in this assay, from the lowest: compounds 4, 1, 3 and 2 (each within the scatter of the next).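

In this assay, the change at this place, on an aromatic carbon para to a group of 7 heavy atoms, gives a 1.2-fold lower number from compound 1 to compound 4 (0.07 log units; within the scatter), so this position now has a measured swap of its own, where earlier only a swap in another pair of compounds could be consulted. The change removes methoxy, with its 2 heavy atoms and 1 hydrogen-bond acceptor, and introduces bromo, with 1 heavy atom and 0 hydrogen-bond acceptors, yet these differences in the counted atoms and acceptors come with no step beyond the scatter, and both single swaps now on record, this one and a 1.0-fold lower number from compound 2 to compound 3 (0.00 log units; within the scatter), stay within it. No supporting measurement bears on why the dose stays within the scatter across this change.

The compounds shown leave open whether an amine, a carboxylic acid or a longer chain on this aromatic carbon would shift the dose beyond the scatter. They also leave open whether methyl or chloro at this same place would give a dose within the scatter of compound 1 and compound 4.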